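The source may report more compounds than this note shows. Statements on the series, on what has been measured and on what is new or still open speak of the compounds shown alone.

- compound 1 `OC[C@H]1O[C@H](OCc2cn(-c3cccc(F)c3)nn2)[C@@H](O)[C@@H](O)[C@@H]1O`: 0.18
- compound 2 `Cc1ccc(-c2cn(C[C@H]3O[C@H](CO)[C@@H](O)[C@H](O)[C@@H]3O)nn2)cc1`: 0.23
- compound 3 `OC[C@H]1O[C@H](Cn2cc(-c3cccc(Cl)c3)nn2)[C@@H](O)[C@@H](O)[C@@H]1O`: 0.68

In a physicochemical assay for lipophilicity, read by LC-MS, using the shake flask method, in phosphate buffer, measured as octanol-water partition, with a stated time of 2 h, at pH 7.4 (on this read-out higher numbers stand for higher lipophilicity and lower numbers for lower lipophilicity), compound 3 has the highest of these three numbers, 0.68, and its gaps to the other two lie beyond the scatter. Compound 4 `OC[C@H]1O[C@H](Cn2cc(COc3ccccc3)nn2)[C@@H](O)[C@@H](O)[C@@H]1O` has not been measured. It carries phenoxymethyl in place of 3-chlorophenyl on an aromatic carbon of a five-membered aromatic ring with 3 nitrogen: phenoxymethyl in place of 3-chlorophenyl on an aromatic carbon. Among the measured compounds shown here, only one measured step changes a group at this place: a number 0.45 log units higher from compound 2 to compound 3 (beyond the scatter). It involves 3-chlorophenyl and 4-methylphenyl, not phenoxymethyl, so it is only a rough guide to size. Starting from the top of the set, a downward step of similar size seems likely. The expected change is a number 0.43 log units lower from compound 3 to compound 4 (beyond the scatter). For compound 4 the estimated value is 0.25, with an expected range from -0.15 to 0.65.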

Compound 4, distribution coefficient: -0.83
For compound 4 the middle estimate is 1.08 log units above the measured one; measured number below the stated range.
By their numbers in this assay, from the lowest: compound 4; then compounds 1 and 2 (each within the scatter of the next); then compound 3.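

In this assay, among the compounds shown here, this place on the five-membered ring allows far larger shifts than the earlier compounds showed: a number 1.51 log units lower from compound 3 to compound 4 (beyond the scatter) and a number 1.06 log units lower from compound 2 to compound 4 (beyond the scatter), both large, whereas a number 0.45 log units higher from compound 2 to compound 3 (beyond the scatter) is modest. Phenoxymethyl keeps a six-membered aromatic ring of carbon only, but unlike 3-chlorophenyl it holds an oxygen and a hydrogen-bond acceptor. No measurement shown here accounts for the drop. As far as these compounds go, it remains open whether the drop goes with the oxygen or with the longer link to the aromatic ring. A phenethyl group, with carbon in place of that oxygen, would separate the two.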